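Piperazine aryl swap: nitrile for dimethylphenyl

The source may report more compounds than this note shows. Statements on the series, on what has been measured and on what is new or still open speak of the compounds shown alone.

Three members of the series have numbers in a functional assay on HL-60 cells (Homo sapiens) for inhibition, read by MTT assay, with a stated time of 72 h; a higher number here means a weaker inhibitor, a lower number a stronger inhibitor. Compound 1 `Cc1nc(-c2ccccc2)c(C(=O)N2CCN(c3cccc(C(N)=O)c3)CC2)o1` gives 71 nM. Compound 2 `Cc1nc(-c2cccc(O)c2)c(C(=O)N2CCN(c3cccc(Cl)c3)CC2)o1` gives 105 nM. Compound 3 `Cc1nc(-c2ccccc2)c(C(=O)N2CCN(c3c(C)cccc3C)CC2)o1` gives 146 nM, the highest of the three numbers; its gap to compound 2 is within the scatter, while its gap to compound 1 is beyond it, as shown by the step of a 2.1-fold higher number from compound 1 to compound 3 (0.31 log units; beyond the scatter).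

Compound 4 `Cc1nc(-c2ccccc2)c(C(=O)N2CCN(c3cccc(C#N)c3)CC2)o1` is not yet measured. It differs from compound 3 in one place: 3-cyanophenyl in place of 2,6-dimethylphenyl on an amine nitrogen in a ring. Among the measured compounds shown here, the only measured step that touches the same position is a 2.1-fold higher number from compound 1 to compound 3 (0.31 log units; beyond the scatter), in which a 3-substituted phenyl group on the ring nitrogen was exchanged for 2,6-dimethylphenyl and the number rose modestly. Compound 4 returns a 3-substituted phenyl to that nitrogen, so the reverse movement is the natural reference: a modest drop in number from compound 3, on the order of that step. For the measured compounds named here, no measured pair compares 3-cyanophenyl with 3-carbamoylphenyl, so the finer position of compound 4 relative to compound 1 cannot be fixed from these data.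

Compound 4 is therefore expected to show a step of a 1.8-fold lower number from compound 3 to compound 4 (0.26 log units; within the scatter) in this assay. The estimate for compound 4 is 80 nM, with a range from 40 nM to 160 nM.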

Compound 4, half-maximal inhibitory concentration: 39.6 nM
Compound 4: middle estimate off by 2.0-fold (0.31 log units), on the high side, and the stated range ends above it.
By their numbers in this assay, from the lowest: compounds 4, 1, 2 and 3 (each within the scatter of the next, the first and the last beyond it).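

In this assay, a 3.7-fold lower number from compound 3 to compound 4 (0.57 log units; beyond the scatter) puts a second 3-substituted phenyl group clear of 2,6-dimethylphenyl on the amine nitrogen in the ring, so the gap seen earlier in a 2.1-fold higher number from compound 1 to compound 3 (0.31 log units; beyond the scatter) no longer rests on the carbamoyl group alone. The two 3-substituted groups are not separated from each other, since a 1.8-fold lower number from compound 1 to compound 4 (0.25 log units; within the scatter) stays inside the scatter, and nitrile and carbamoyl read as equivalent on this aromatic carbon in these data. The exchange from 2,6-dimethylphenyl to 3-cyanophenyl leaves the count of 8 heavy atoms unchanged, and no measurement available here bears on why the number moves.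

The step from compound 3 changes the identity and the placement of the substituents together, so a 3-methylphenyl or a 2-cyanophenyl group on this nitrogen would be needed to tell those two changes apart. Going by these compounds, how far the 3-position tolerates other groups also stays open, for instance a carboxylic acid, a primary amine or a longer chain ending in a nitrile.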